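Hexadecyl Carbamates and an Ester Tested for Acid Amidase Inhibition

The source may report more compounds than this note shows. Statements on the series, on what has been measured and on what is new or still open speak of the compounds shown alone.

Measured so far:
- Compound 1, `CCCCCCCCCCCCCCCCOC(=O)C1CCCC1`: 17%
- Compound 2, `CCCCCCCCCCCCCCCCOC(=O)NC1CCCCC1`: "not active" (no number reported)

Of the compounds shown here, two have been tested in an assay on HEK293 cells for inhibition of N-acylethanolamine-hydrolyzing acid amidase (Homo sapiens), read by scintillation counting, tested at 50 uM; a higher number here means more inhibition at the concentration tested (going by the name of the read-out), a lower number less inhibition. Compound 1 gives 17% in this assay. Compound 2 is reported as "not active" (no number reported) in this assay, so no single number stands for it; it cannot be placed above or below compound 1 on the numbers shown, only noted as giving no reportable inhibition at the concentration used.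

Compound 3, `CCCCCCCCCCCCCCCCOC(=O)Nc1ccc(OC)cc1`, has not been measured. It differs from compound 2 in one place: 4-methoxyphenyl in place of cyclohexyl on an amide-type nitrogen. Within the data shown here, with no number for compound 2 and no step between measured compounds, the size of the change in this assay cannot be read from the data. Among the measured compounds shown here, the only measured compound with a number, compound 1, gives 17%, a low value, and compound 2 gives none, so a step in either direction beyond the scatter is not expected.

Compound 3 is estimated to give 12% in this assay, within a range of 0% to 35%, and it may well again be reported without a number.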

Compound 3, a percentage reported as inhibition, at one concentration (the size of the read-out at that concentration, not a potency): "not active" (no number reported)
Compound 3: no number reported; there is nothing to compare the estimate with.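

In this assay compound 2 gives "not active" (no number reported) and compound 3 gives "not active" (no number reported), so no step can be read between these two compounds. The compounds shown leave open whether cyclohexyl and 4-methoxyphenyl on the amide-type nitrogen differ at all in their effect on inhibition. Nothing available bears on this result.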